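The compounds below may be only part of what the source reports. "The series", "measured", "known", "first", "only" and "open" are said of these compounds alone.

Measured so far in an ADME assay (liver) for metabolic stability, with Liver microsome (Rattus norvegicus) as the target, read by LC-MS, using microsomes and NADPH, with stated times of 5 min and 60 min, tested at 4 uM; on this read-out lower numbers stand for a less stable compound and higher numbers for a more stable compound:
compound 1 `COc1cc(C(=O)O)ccc1OCCCCOc1ccc(C(=O)CC(C)(C)C)c(O)c1C`: 49%
compound 2 `COc1cc(C(=O)O)ccc1OCCCCOc1ccc(C(=O)CC(C)C)c(O)c1C`: 43%
compound 3 `COc1ccc(C(=O)O)cc1OCCCCOc1ccc(C(=O)CC2CCCC2)c(O)c1C`: 14%

Compound 2 stands second highest of the three numbers in this assay. Its nearest neighbour is compound 1, and that gap, a number 6 percentage points lower from compound 1 to compound 2 (within the scatter), lies within the scatter. Compound 3 is the furthest, its number lying below that of compound 2 by more than the scatter; compound 3 differs from compound 2 in more than one place, so nothing is drawn from that gap.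

Compound 4 `Cc1c(OCCCCOc2ccc(C(=O)O)cc2F)ccc(C(=O)CC(C)C)c1O` differs from compound 2 in one place: fluoro in place of methoxy on an aromatic carbon. Among the measured compounds shown here, none of the measured steps removes a methoxy or introduces a fluoro; the only single-point step, a number 6 percentage points lower from compound 1 to compound 2 (within the scatter), concerns a methyl on a saturated chain carbon and says nothing about this exchange. For the measured compounds named here, with no bearing step in hand, no step beyond the scatter is expected in this assay from compound 2 to compound 4, and the expected step is a number 5 percentage points higher from compound 2 to compound 4 (within the scatter). Going by the values given here, compound 4 is therefore estimated at 48%, in the range 30% to 66%; the range is kept wide, as no measured step covers this exchange.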

Compound 4, percent of the compound remaining: 57%
Compound 4: the middle estimate sits 9 percentage points below what was measured, within the range that was stated.
By their numbers in this assay, from the lowest: compound 3; then compounds 2, 1 and 4 (each within the scatter of the next, the first and the last beyond it).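

At the aromatic carbon ortho to a large group and meta to a carboxy group, fluoro in place of methoxy gives a number 14 percentage points higher from compound 2 to compound 4 (beyond the scatter) in this assay. This is the only single-place step shown that lies beyond the scatter, and it is rated modest. Among the compounds shown here, the sole earlier step, a number 6 percentage points lower from compound 1 to compound 2 (within the scatter), concerned a methyl on the saturated chain, so the read-out is now seen to shift with an exchange on the aromatic ring that carries the carboxy group. Nothing measured accounts for this step.

On these data alone, whether the shift goes with the entry of fluoro or the departure of methoxy stays open; hydrogen, chloro or hydroxy on this carbon would separate the two. Also open, as far as these compounds go, is whether the same exchange holds with the chain of compound 1 in place of that of compound 2.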